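The source may report more compounds than this note shows. Statements on the series, on what has been measured and on what is new or still open speak of the compounds shown alone.

Compound 1, `NC(=O)N1CCN(C(=S)SCc2cn(Cc3ccccc3F)nn2)CC1`, gives in a functional assay on SMMC-7721 cells (Homo sapiens) for cytotoxicity, read by MTT assay, with a stated time of 72 h (on this read-out higher numbers stand for weaker inhibition and lower numbers for stronger inhibition), the limit > 128000 nM.
Compound 2, `CCNC(=O)N1CCN(C(=S)SCc2cn(Cc3ccccc3F)nn2)CC1`, gives in this assay the limit > 128000 nM.

Both values are limits of the assay rather than numbers: neither compound inhibited the cells strongly enough to be read within the range tested. The step that the two limits leave unreadable from compound 1 to compound 2 puts an ethyl group where a hydrogen sat on the amide-type nitrogen, and because both ends rest at a limit its size cannot be read; the only thing known about it is the limit of > 128000 nM in this assay, at which 2 of the 2 values shown sit. Compound 2 therefore stands at the weak end of what this assay can report, with no number of its own.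

Compound 3, `CC(C)NC(=O)N1CCN(C(=S)SCc2cn(Cc3ccccc3F)nn2)CC1`, has not yet been measured. Compared with compound 2 the change is methyl in place of hydrogen on a saturated chain carbon bound to an amide-type nitrogen and a saturated chain carbon. For the measured compounds named here, the one measured step bears on it only loosely, since it extends the same chain on the same nitrogen and its size is unreadable, so it gives no direction to expect beyond the scatter. Compound 3 is therefore expected near 200000 nM, between 100000 nM and 500000 nM. That estimate means an expected step that the limit leaves unreadable from compound 2 to compound 3 within the scatter, most likely reported again as a limit.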

Compound 3, half-maximal inhibitory concentration: 7130 nM
Compound 3: the middle estimate sits 28-fold (1.45 log units) above what was measured, outside the stated range (below it).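

In this assay, for the compounds shown here, the isopropyl group on this amide-type nitrogen gives the first readable number, and adding one methyl on a saturated chain carbon bound to an amide-type nitrogen and a saturated chain carbon makes a large difference: an at least 17-fold lower number from compound 2 to compound 3 (1.25 log units; beyond the scatter). Replacing the amide hydrogen with the whole isopropyl group gives a step of the same printed size, an at least 17-fold lower number from compound 1 to compound 3 (1.25 log units; beyond the scatter), while the step from hydrogen to ethyl cannot be read, and the two readable steps are minimum sizes that could prove larger. Among these compounds, adding carbon to this nitrogen is not enough in itself, as the ethyl group of compound 2 goes against that simple reading, and only the isopropyl group leaves the limit behind: the limit of > 128000 nM in this assay, at which 2 of the 3 values shown sit.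

From the compounds shown here alone, whether the gain depends on the branched form of isopropyl or simply on having one more carbon stays open, and a straight propyl chain, a cyclopropyl ring or a tert-butyl group at this place would help separate the two. Going by these compounds, it is also open whether the isopropyl group would give a similar step in other cell lines.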